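The source may hold more compounds than are shown below. What is called first, only, known or untested is meant among the compounds shown, and "the series" means these compounds.

Compound 3 `NC(=O)c1c(NC(=O)c2ccccc2Cl)sc2c1CCN(C(=S)Nc1cccc3ccccc13)C2` is the starting point of this step. In a functional assay on HeLa cells (Homo sapiens) for antiproliferative activity, with a stated time of 24 h (on this read-out lower numbers stand for stronger inhibition and higher numbers for weaker inhibition), compound 3 gives 30800 nM. Compound 2 `NC(=O)c1c(NC(=O)c2cccc([N+](=O)[O-])c2)sc2c1CCN(Cc1c(Cl)cccc1Cl)C2`, with a different substitution pattern on the shared core, gives 46100 nM in this assay, which sits within the scatter of the number for compound 3, so the two are not ranked against each other. Compound 1 `NC(=O)c1c(NC(=O)c2ccccc2Cl)sc2c1CCN(Cc1ccc(Cl)cc1)C2` is reported in this assay only as a limit, > 50000 nM. That limit, (the limit of > 50000 nM in this assay, at which 1 of the 3 values shown sits), leaves no number for compound 1 to set beside the other two.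

Compound 4 `NC(=O)c1c(NC(=O)c2ccccc2Cl)sc2c1CCN(C(=S)Nc1ccccc1C(F)(F)F)C2` differs from compound 3 in one place: 2-(trifluoromethyl)phenyl in place of naphthalen-1-yl on an amide-type nitrogen. Going by the values given here, no measured pair in the set shows this change, so no step size can be read off for it. The expectation in this assay is a step from compound 3 to compound 4 of a 1.1-fold higher number from compound 3 to compound 4 (0.06 log units; within the scatter), that is nothing beyond the scatter. Compound 4 is accordingly estimated at 35000 nM, with a range from 12000 nM to 100000 nM. Given the numbers of this series, a result reported only as a limit is a real possibility.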

Compound 4, half-maximal inhibitory concentration: 26700 nM
Estimate against measurement, compound 4: 1.3-fold (0.12 log units) above; the measured number falls inside the stated range.
By their numbers in this assay, from the lowest: compounds 4, 3 and 2 (each within the scatter of the next). At a limit, above all of these: compound 1.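

Going by these compounds alone, this is the first comparison that differs in one place: on the amide-type nitrogen whose other neighbour is the thiocarbonyl carbon, 2-(trifluoromethyl)phenyl replaces naphthalen-1-yl with a 1.2-fold lower number from compound 3 to compound 4 (0.06 log units; within the scatter) in this assay. The swap goes from two six-membered aromatic rings to one at the same count of heavy atoms, yet the two numbers lie within the scatter of each other, so the second aromatic ring is not required for a number of this size. Nothing among the data shown gives a reason for this step.

Open, as far as these compounds go, is whether a group without an aromatic ring at this nitrogen, such as cyclohexyl or a longer alkyl chain, gives a step beyond the scatter. Also open, from the compounds shown here alone, is whether a phenyl ring carrying an amine or a carboxylic acid does so.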